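A few compounds are considered here, and "the series" means these few. Any claim that something is new, unique, unknown or untested is made for them only; others in the source may bear on it.

Compound 3, `CCCCCCCCCCCCCCNC(=O)[C@@H](NC(=O)/C=C/c1ccccc1)[C@@H](C)O`, was tested in a functional assay on HepG2 cells (Homo sapiens) for cytotoxicity, read by MTT assay, with a stated time of 48 h (a lower number here means a stronger inhibitor, a higher number a weaker inhibitor), where compound 3 gives 150000 nM. Among the compounds with values here, of the three compounds measured so far it carries the highest number. Compound 1, `CCCCCCCCCCCCCCNC(=O)[C@@H](NC(=O)c1cccs1)[C@@H](C)O`, gives 88400 nM in this assay, and the step of a 1.7-fold higher number from compound 1 to compound 3 (0.23 log units; within the scatter) lies within the scatter. Compound 2, `CCCCCCCCCCCCCCNC(=O)[C@@H](NC(=O)c1cc2ccccc2o1)[C@@H](C)O`, gives 23400 nM in this assay, and the step of a 6.4-fold higher number from compound 2 to compound 3 (0.81 log units; beyond the scatter) is beyond the scatter, as is the step of a 3.8-fold lower number from compound 1 to compound 2 (0.58 log units; beyond the scatter).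

Compound 4, `CCCCCCCCCCCCCCCCCCNC(=O)[C@@H](NC(=O)/C=C/c1ccccc1)[C@@H](C)O`, differs from compound 3 by butyl in place of hydrogen on a saturated chain carbon, ten or more bonds along the chain from an amide-type nitrogen. Within the data shown here, all three measured steps exchange the group on the carbonyl carbon; none of them touches the saturated chain, so no measured step bears directly on this change. With nothing to compare, the expectation is that the step of a 1.3-fold lower number from compound 3 to compound 4 (0.10 log units; within the scatter) stays within the scatter. Compound 4 is therefore estimated at 120000 nM in this assay, with a range from 45000 nM to 300000 nM.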

Compound 4, half-maximal inhibitory concentration: 128000 nM
Compound 4: the middle estimate sits 1.1-fold (0.03 log units) below what was measured; the measured number falls inside the stated range.
By their numbers in this assay, from the lowest: compound 2; then compounds 1, 4 and 3 (each within the scatter of the next).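

In this assay, butyl in place of hydrogen on a saturated chain carbon, ten or more bonds along the chain from an amide-type nitrogen, gives a 1.2-fold lower number from compound 3 to compound 4 (0.07 log units; within the scatter). This is the only step shown that changes the saturated chain rather than the group on the carbonyl carbon, and with 2-phenylethenyl on the carbonyl carbon, adding butyl leaves the two numbers within the scatter, whereas two of the three carbonyl-carbon exchanges went beyond it. No independent evidence bears on this result, so it remains an observation without an explanation.

The compounds shown leave open whether butyl on the chain would behave the same way with thiophen-2-yl or 1-benzofuran-2-yl on the carbonyl carbon. They also leave open the effect of a much shorter chain, such as hexyl, or of an amine or a carboxylic acid on the chain.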